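Chloro in place of methoxy: expected solubility of compound 4

The compounds below may be only part of what the source reports. "The series", "measured", "known", "first", "only" and "open" are said of these compounds alone.

In a physicochemical assay for solubility, in phosphate buffer, measured as kinetic solubility, with a stated time of 24 h, at pH 6.5 (on this read-out higher numbers stand for higher solubility and lower numbers for lower solubility), compound 3 `COc1cnc(-c2cc(Oc3ccc(S(C)(=O)=O)cc3)cc(OC(C)C)c2)[nH]c1=O` gives 7100 nM and stands second highest of three numbers. Compound 2 `Cc1cc(=O)[nH]c(-c2cc(Oc3ccc(S(C)(=O)=O)cc3)cc(OC(C)C)c2)n1` gives 15000 nM at the top, and compound 1 `Cc1cnc(-c2cc(Oc3ccc(S(C)(=O)=O)cc3)cc(OC(C)C)c2)[nH]c1=O` gives 1900 nM at the bottom. Compound 4 `CC(C)Oc1cc(Oc2ccc(S(C)(=O)=O)cc2)cc(-c2ncc(Cl)c(=O)[nH]2)c1` differs from compound 3 by chloro in place of methoxy on an aromatic carbon with chloro in place of methoxy on an aromatic carbon. The nearest measured change is methoxy in place of methyl, seen in a 3.7-fold higher number from compound 1 to compound 3 (0.57 log units; beyond the scatter) on the same carbon. The steps of a 7.9-fold higher number from compound 1 to compound 2 (0.90 log units; beyond the scatter) and a 2.1-fold lower number from compound 2 to compound 3 (0.32 log units; beyond the scatter) exchange the whole ring group and bear less directly. Among the compounds with values here, no chloro compound has been measured, so a 3.7-fold higher number from compound 1 to compound 3 (0.57 log units; beyond the scatter) is expected to reverse only in part. The expected step is a 2.4-fold lower number from compound 3 to compound 4 (0.37 log units; beyond the scatter) in this estimate. Compound 4 is estimated at 3000 nM within a range of 1000 nM to 9000 nM overall.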

Compound 4, solubility: 24000 nM
Beside the measured number, compound 4's estimate is 8.0-fold (0.90 log units) below it; measured number outside the range, above it.
By their numbers in this assay, from the lowest: compound 1; then compound 3; then compounds 2 and 4 (each within the scatter of the next).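

In this assay chloro on this aromatic carbon gives a higher number than methoxy (a 3.4-fold higher number from compound 3 to compound 4 (0.53 log units; beyond the scatter)) and than methyl (a 13-fold higher number from compound 1 to compound 4 (1.10 log units; beyond the scatter)), so the order at this carbon runs methyl, methoxy, chloro. Chloro here reaches the level of the methyl-shifted isomer, with no order between the two (a 1.6-fold higher number from compound 2 to compound 4 (0.20 log units; within the scatter)). Nothing measured here accounts for these steps. As far as these compounds go, whether fluoro, nitrile or an amine on this carbon would fall within that order remains open. So does whether chloro keeps its step with a group other than isopropoxy on the core.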